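Triazole aryl substituents on the shared core, antiproliferative read-out

A few compounds are considered here, and "the series" means these few. Any claim that something is new, unique, unknown or untested is made for them only; others in the source may bear on it.

Measured compounds:
- compound 1, `O=C1O[C@H]([C@@H](O)Cn2cc(-c3cccc(O)c3)nn2)C(OCc2ccccc2)=C1OCc1ccccc1`: 51800 nM
- compound 2, `C[Si](C)(C)c1cn(C[C@H](O)[C@H]2OC(=O)C(OCc3ccccc3)=C2OCc2ccccc2)nn1`: 12100 nM
- compound 3, `COc1ccc(-c2cn(C[C@H](O)[C@H]3OC(=O)C(OCc4ccccc4)=C3OCc3ccccc3)nn2)cc1`: 99700 nM

In a functional assay on MCF7 cells (Homo sapiens) for antiproliferative activity, read by MTT assay, with a stated time of 72 h (on this read-out higher numbers stand for weaker inhibition and lower numbers for stronger inhibition), compound 3 gives the highest number of the three. Its nearest neighbour is compound 1, with a 1.9-fold higher number from compound 1 to compound 3 (0.28 log units; within the scatter); the step from compound 2, an 8.2-fold higher number from compound 2 to compound 3 (0.92 log units; beyond the scatter), is the larger one. The series therefore shows one clear effect, the trimethylsilyl group versus an aryl group on the triazole (a 4.3-fold lower number from compound 1 to compound 2 (0.63 log units; beyond the scatter)), and one change of aryl group that stays within the scatter.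

Compound 4, `COc1ccccc1-c1cn(C[C@H](O)[C@H]2OC(=O)C(OCc3ccccc3)=C2OCc2ccccc2)nn1`, is not yet measured. Its difference from compound 3 is 2-methoxyphenyl in place of 4-methoxyphenyl on an aromatic carbon.

For the measured compounds named here, no measured step moves the methoxy group around the phenyl ring, so no step bears directly on this change. Going by the values given here, the only step that alters the aryl substituent while keeping an aryl group, compound 1 to compound 3, lies within the scatter; this is the closest guide. A step within the scatter, in either direction, is therefore expected in this assay, with somewhat more chance of a lower number than a higher one given that compound 3 already holds the highest number.

Compound 4 is estimated at 70000 nM, range 25000 nM to 200000 nM, meaning an expected step of a 1.4-fold lower number from compound 3 to compound 4 (0.15 log units; within the scatter).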

Compound 4, half-maximal inhibitory concentration: > 100000 nM
Compound 4: only a limit was reported; the forecaster's own chance of this, stated with the estimate: 25%; at least 1.4-fold (0.15 log units) between middle value and limit.
By their numbers in this assay, from the lowest: compound 2; then compounds 1 and 3 (each within the scatter of the next). At a limit, above all of these: compound 4.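

Compound 4 gives only a limit, not a number, in this assay: the limit of > 100000 nM in this assay, at which 1 of the 4 values shown sits. The step that exchanges 4-methoxyphenyl for 2-methoxyphenyl cannot be read, so this change of methoxy position has no measured size. The gap from the trimethylsilyl group now extends to a third aryl group, with an at least 8.2-fold higher number from compound 2 to compound 4 (0.91 log units; beyond the scatter), whereas the comparison with 3-hydroxyphenyl gives an at least 1.9-fold higher number from compound 1 to compound 4 (0.28 log units; that floor lies within the scatter), which establishes no difference between those two aryl groups.

On these data alone, the actual value of compound 4 remains open, and with it any ordering among the 2-methoxyphenyl, 3-hydroxyphenyl and 4-methoxyphenyl groups. On the change of methoxy position, the new result gives only a number no lower from compound 3 to compound 4 (the limit leaves the size open).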